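A few compounds are considered here, and "the series" means these few. Any claim that something is new, unique, unknown or untested is made for them only; others in the source may bear on it.

Measured compounds:
- compound 1, `CN1C(=O)C(c2ccccc2)CC(c2ccccc2)C1=O`: 14.8 mg/kg
- compound 2, `O=C1NC(=O)C(c2ccccc2Cl)CC1c1ccccc1Cl`: 25.5 mg/kg

Both compounds were tested in a functional assay on the whole organism (strain Swiss albino) with Mus musculus as the target, in the maximal electroshock model, with a stated time of 2 h; on this read-out lower numbers stand for an effect already at smaller amounts and higher numbers for an effect only at larger amounts of compound. Compound 1 gives 14.8 mg/kg in this assay, and compound 2 gives 25.5 mg/kg. Of the two numbers recorded, that of compound 2 is the higher one, but its nearest neighbour is compound 1 and the gap between them lies within the usual scatter of such measurements, so the two values are best read as alike. Among the measured compounds shown here, the two structures differ in more than one place, so no single step connects them.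

Compound 3, `Cc1ccc(N2C(=O)C(c3ccccc3Cl)CC(c3ccccc3Cl)C2=O)cc1`, has not yet been measured. It is built from compound 2 by one change: 4-methylphenyl in place of hydrogen on an amide-type nitrogen in a ring. For the measured compounds named here, no pair of measured compounds shows what this kind of change does in this assay, so there is no template for the size of the step. With the shared core otherwise unchanged, the most plausible expectation is that the step from compound 2 to compound 3 is small, a 1.2-fold lower number from compound 2 to compound 3 (0.06 log units; within the scatter), without a clear direction beyond the scatter. On that basis compound 3 is estimated at 22 mg/kg in this assay, with a range from 8 mg/kg to 60 mg/kg expected.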

Compound 3, dose for half-maximal effect: 41.2 mg/kg
Compound 3: middle estimate off by 1.9-fold (0.27 log units), on the low side; low and high end bracket the measured number.
By their numbers in this assay, from the lowest: compounds 1, 2 and 3 (each within the scatter of the next, the first and the last beyond it).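

In this assay, among the compounds shown here, the step at this position can now be read for the first time: it is a 1.6-fold higher number from compound 2 to compound 3 (0.21 log units; within the scatter), made by 4-methylphenyl in place of hydrogen on the amide-type nitrogen in a ring. The values of the two compounds are therefore best read as alike, even though the entering group brings 7 heavy atoms and a six-membered aromatic ring where only a hydrogen atom stood before. For the compounds shown here, for this one pair, then, a substantial addition at this nitrogen leaves the number within the usual scatter of repeated measurements, which the earlier compounds could not show because they offered no single-change comparison.

As far as these compounds go, what a different group on this nitrogen would do, such as an amine or a carboxylic acid carried on a short carbon chain, stays open, as does whether 4-methylphenyl would give a similar step on another core. The data shown also hold no measurement that would explain the result of this change.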